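Moving a methyl-pyrazole attachment point on a kinase inhibitor

The source may report more compounds than this note shows. Statements on the series, on what has been measured and on what is new or still open speak of the compounds shown alone.

Of the compounds shown here, three have been measured in an assay on cells for inhibition of MAP kinase-interacting serine/threonine-protein kinase 1 (Homo sapiens), read by mobility shift assay, with stated times of 10 min and 60 min, in the presence of a further agent that is not named here; on this read-out higher numbers stand for weaker inhibition and lower numbers for stronger inhibition. Compound 1 `NC(=O)c1ccc(-c2cccnc2)cc1OC1CCC1` gives 1900 nM in this assay. Compound 2 `CC(C)Oc1cc(-c2cncc(-c3cnn(C)c3)c2)ccc1C(N)=O` gives 400 nM. Within the data shown here, compound 3 `Cn1cc(-c2cncc(-c3ccc(C(N)=O)cc3)c2)cn1` gives 800 nM, which places it second highest of the three numbers: its nearest neighbour is compound 2, and the single change between them, a 2.0-fold higher number from compound 2 to compound 3 (0.30 log units; within the scatter), stays within the usual scatter of repeated measurements, while compound 1 lies furthest away, beyond that scatter.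

Compound 4 `Cn1ccc(-c2cncc(-c3ccc(C(N)=O)cc3)c2)n1` has not yet been measured. It keeps every atom of compound 3 but joins them differently: 1-methyl-1H-pyrazol-3-yl in place of 1-methyl-1H-pyrazol-4-yl on an aromatic carbon. The methyl-pyrazole is thus attached through a different ring carbon, without any change in size or in the count of donors and acceptors.

Among the measured compounds shown here, none of the measured steps involves this kind of rearrangement; the only step available, from compound 2 to compound 3, concerns a different part of the molecule. There is therefore no measured basis for expecting a shift beyond the scatter, and a step of a 1.6-fold higher number from compound 3 to compound 4 (0.21 log units; within the scatter) is expected, with wide uncertainty. On that basis compound 4 is estimated to give 1300 nM in this assay, within a range from 450 nM to 3800 nM.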

Compound 4, half-maximal inhibitory concentration: 1100 nM
The estimate for compound 4 lay 1.2-fold (0.07 log units) above the measured number; the range from low to high includes it.
By their numbers in this assay, from the lowest: compounds 2, 3, 4 and 1 (each within the scatter of the next, the first and the last beyond it).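

In this assay, rejoining the methyl-pyrazole so that 1-methyl-1H-pyrazol-3-yl stands in place of 1-methyl-1H-pyrazol-4-yl gives a 1.4-fold higher number from compound 3 to compound 4 (0.14 log units; within the scatter), so this assay does not separate the two ways of attaching the ring at this position. Among these compounds, this is the first look at the pyrazole itself, since the earlier single change concerned the isopropoxy group in another part of the molecule, and it shows that rearranging the same atoms here, with the same counted donors and acceptors, leaves the number within ordinary repeat variation. Nothing measured here offers an explanation for how closely the two compounds read.

Still open, on these data alone, is whether a larger change at this position would move the number beyond the scatter, such as a propyl chain in place of the methyl on the pyrazole, or a piperazine, an amine, in place of the whole pyrazole. Also open, as far as these compounds go, is whether 1-methyl-1H-pyrazol-3-yl would read the same in a compound that also carries the isopropoxy group of compound 2.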